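This account rests on a few compounds, and the source may have more. Where it says the series, first, only, none or still open, it means among the compounds named here.

Compound 1 `CC(C)(C)OC(=O)N1CCN(C(=S)SCc2cn(Cc3ccc(Cl)cc3)nn2)CC1` is a piperazine dithiocarbamate that carries a tert-butyl carbamate at one end and a triazole at the other. In a functional assay on MCF7 cells (Homo sapiens) for inhibition, read by MTT assay, with a stated time of 72 h (a higher number here means a weaker inhibitor, a lower number a stronger inhibitor), compound 1 gives 2960 nM. Compound 3 `O=C(OCc1ccccc1)N1CCN(C(=S)SCc2cn(Cc3ccc(Cl)cc3)nn2)CC1` differs from it only at the carbamate, with benzyl in place of tert-butyl on an oxygen next to a carbonyl group, and in this assay compound 3 gives 27500 nM; that step is a 9.3-fold higher number from compound 1 to compound 3 (0.97 log units; beyond the scatter). Compound 2 `S=C(SCc1cn(Cc2ccc(Cl)cc2)nn1)N1CCNCC1` has the free piperazine, but for compound 2 the result in this assay is "not determined" (no result reported). Among the two numbers at hand, compound 1 therefore stands as the lower one.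

Compound 4 `COc1ccc(-n2cc(CSC(=S)N3CCN(C(=O)OC(C)(C)C)CC3)nn2)cc1` is reached from compound 1 by a change at the other end of the molecule: 4-methoxyphenyl in place of 4-chlorobenzyl on an aromatic nitrogen. Going by the values given here, no measured step touches that position; the single step between compound 1 and compound 3 concerns the carbamate and so says nothing about what a 4-methoxyphenyl in place of a 4-chlorobenzyl on the aromatic nitrogen will do. Without a comparable step, no direction can be expected beyond the scatter, and the estimate stays close to compound 1 with a wide range. In this assay compound 4 is expected to give 5000 nM, between 1200 nM and 25000 nM, which means an estimated step of a 1.7-fold higher number from compound 1 to compound 4 (0.23 log units; within the scatter).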

Compound 4, half-maximal inhibitory concentration: 93100 nM
For compound 4 the middle estimate is 19-fold (1.27 log units) below the measured one, and the stated range ends below it.
By their numbers in this assay, from the lowest: compound 1; then compound 3; then compound 4.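

Going by these compounds alone, the aromatic nitrogen of the five-membered ring, which no earlier step had touched, proves sensitive in this assay: replacing 4-chlorobenzyl with 4-methoxyphenyl gives a 31-fold higher number from compound 1 to compound 4 (1.50 log units; beyond the scatter), a large step towards weaker inhibition. This end of the molecule therefore counts as well as the carbamate end, and with a 9.3-fold higher number from compound 1 to compound 3 (0.97 log units; beyond the scatter) as the other step, both changes shown lead away from compound 1 to a weaker inhibitor, leaving compound 1 with the lowest number of the three. Whether the new step follows from benzyl giving way to phenyl or from chlorine giving way to methoxy cannot be told from these compounds, and no measurement at hand speaks to its cause.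

Left open is whether 4-chlorophenyl or 4-methoxybenzyl on the same aromatic nitrogen would read close to compound 1 or close to compound 4, a pair of results that would separate the two parts of this change. Also open, on these data alone, is how a longer chain such as 2-phenylethyl on that nitrogen would read in this assay.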